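Solubility notes: aryl replacement on the shared core

The source may report more compounds than this note shows. Statements on the series, on what has been measured and on what is new or still open speak of the compounds shown alone.

Compound 1, `Cc1ccccc1-c1nc(CN2CCC(C(=O)NCCCN3CCC(C)(C)CC3)CC2)c(C)o1`: in a physicochemical assay for solubility, in phosphate buffer, measured as kinetic solubility, at pH 7.4 (a lower number here means a less soluble compound, a higher number a more soluble compound), compound 1 gives > 69 ug/mL, a limit of the assay.
Compound 2, `Cc1ccccc1-c1nc(CN2CCC(C(=O)NCCCN3CCCC(CC(C)C)C3)CC2)c(C)o1`: in this assay compound 2 gives 54.9 ug/mL.
Compound 3, `Cc1oc(-c2c(Cl)cccc2C(F)(F)F)nc1CN1CCC(C(=O)NCCCN2C[C@H](C)C[C@H](C)C2)CC1`: in this assay compound 3 gives 65.1 ug/mL.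

Compound 3 stands highest of the two numbers, with compound 2 nearest at a gap within the scatter; compound 1 sits at the limit (the limit of > 69 ug/mL in this assay, at which 1 of the 3 values shown sits). Compound 4, `Cc1ccc(-c2nc(CN3CCC(C(=O)NCCCN4C[C@H](C)C[C@H](C)C4)CC3)c(C)o2)c(C)c1`, differs from compound 3 by 2,4-dimethylphenyl in place of 2-chloro-6-(trifluoromethyl)phenyl on an aromatic carbon. Within the data shown here, the single measured step, an at least 1.2-fold lower number from compound 1 to compound 2 (0.09 log units; that floor lies within the scatter), concerns the saturated ring on the chain and lies within the scatter; no measured step touches the aryl group, so none bears on this change. Compound 4 is therefore expected to show no step beyond the scatter, a 1.1-fold higher number from compound 3 to compound 4 (0.04 log units; within the scatter). The estimate for compound 4 is 72 ug/mL, between 40 ug/mL and 130 ug/mL.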

Compound 4, solubility: > 71 ug/mL
Compound 4: no number, only a limit; the forecaster's own chance of this, stated with the estimate: 45%; the middle value lies beyond the limit too.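

Among these compounds, the first step at this aromatic carbon, 2,4-dimethylphenyl in place of 2-chloro-6-(trifluoromethyl)phenyl, is an at least 1.0-fold higher number from compound 3 to compound 4 (0.03 log units; that floor lies within the scatter), so in this assay the change shows no loss across these two very different aryl groups. Compound 4 gives a limit, not a number: the limit of > 71 ug/mL in this assay, at which 1 of the 4 values shown sits.

On these data alone, the step therefore has a floor but no size, and whether this change moves the read-out beyond the scatter stays open. Also open, as far as these compounds go, is how an aryl group carrying a carboxylic acid or an amine would read at this position in this assay.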